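This account rests on a few compounds, and the source may have more. Where it says the series, first, only, none or still open, it means among the compounds named here.

Compound 1 `CC1=NN(S(=O)(=O)c2ccccc2C)C(c2cc(Br)ccc2O)C1`: 48100 nM
Compound 2 `CC1=NN(S(=O)(=O)c2ccc(F)cc2)C(c2cc(Br)ccc2O)C1`: > 60000 nM (a limit, not a number)

In a functional assay on SGC-7901 cells (Homo sapiens) for antiproliferative activity, read by MTT assay, with a stated time of 48 h (a lower number here means that less compound is needed, a higher number that more compound is needed for the effect), compound 1 gives 48100 nM. Compound 2 has no number here, and it stands at the limit of > 60000 nM in this assay, at which 1 of the 2 values shown sits.

Compound 3 `CC1=NN(S(=O)(=O)c2ccc(Cl)cc2)C(c2cc(Br)ccc2O)C1` differs from compound 2 at one place: chloro in place of fluoro on an aromatic carbon. This is chloro in place of fluoro on an aromatic carbon, para to a large group. For the measured compounds named here, only one measured step bears on this change: an at least 1.2-fold higher number from compound 1 to compound 2 (0.09 log units; that floor lies within the scatter). That step also alters the group on the sulfonyl sulfur, but it replaces a different group, and its floor lies within the scatter. It offers no size to carry over, so no step beyond the scatter is expected in this assay, in either direction. The estimated step is an at least 1.0-fold lower number from compound 2 to compound 3 (0.03 log units; that floor lies within the scatter). A limit rather than a number is also a likely outcome. For compound 3 the expected value is 55000 nM, with an estimated range from 25000 nM to 90000 nM.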

Compound 3, half-maximal effective concentration: > 60000 nM
Compound 3 gave a limit, no number (the forecaster's own chance of this, stated with the estimate: 45%); at least 1.0-fold (0.03 log units) between middle value and limit.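

In this assay, moving from fluoro to chloro at this place, para to a large group, still does not yield a number: compound 3, like compound 2, gives only a limit, so the step between them cannot be read. For the compounds shown here, the one readable step is an at least 1.2-fold higher number from compound 1 to compound 3 (0.09 log units; that floor lies within the scatter), which adds a second 4-substituted phenyl group to the comparison with the 2-methylphenyl group of compound 1, again with a floor inside the scatter. The new result therefore adds one more compound to the limit, and most of the series now rests there: the limit of > 60000 nM in this assay, at which 2 of the 3 values shown sit.

From the compounds shown here alone, how far apart compound 2 and compound 3 truly lie remains open. So does what an amine, a methoxy group or a carboxylic acid at this place would do in this assay.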